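This account rests on a few compounds, and the source may have more. Where it says the series, first, only, none or still open, it means among the compounds named here.

Of the compounds shown here, two with a shared core have so far been tested in an in vitro assay on U2OS cells for agonist activity at neurotensin receptor type 2 (Homo sapiens), read by reporter gene assay and beta-arrestin recruitment; a lower number here means that less compound is needed, a higher number that more compound is needed for the effect. Compound 1, `COc1cc2nc(C3CCC3)nc(N3CCN(c4ccccc4C)CC3)c2cc1OC`, carries a cyclobutyl group on that core. In this assay compound 1 reaches only the limit of the assay, recorded as > 80000 nM. Compound 2, `COc1cc2nc(C)nc(N3CCN(c4ccccc4OC)CC3)c2cc1OC`, carries a methyl group in the same place. In this assay compound 2 likewise reaches only the limit, recorded as > 80000 nM. For the measured compounds named here, compound 2 therefore stands at a limit rather than at a number, and the only other value shown is a limit as well: both sit at the limit of > 80000 nM in this assay, at which 2 of the 2 values shown sit. Going by the values given here, with two limits and no number, no step between measured compounds can be read.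

Compound 3, `COc1cc2nc(CC(C)C)nc(N3CCN(c4ccccc4OC)CC3)c2cc1OC`, differs from compound 2 by isopropyl in place of hydrogen on a saturated chain carbon bound to an aromatic carbon. Both of the measured compounds sit at the limit whether the group on the core is small or larger, so no movement beyond the scatter is expected, and compound 3 is expected to remain at the limit. The expected step of a number no higher from compound 2 to compound 3 (the limit leaves the size open) is essentially none. For compound 3 the estimated value is 80000 nM, with a range from 20000 nM to 300000 nM.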

Compound 3, half-maximal effective concentration: > 80000 nM
Compound 3 ended at the assay's limit (the forecaster's own chance of this, stated with the estimate: 85%); the middle value lies on the limit itself.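

Compound 2 and compound 3 both give a limit rather than a number in this assay, so no step can be read between them. The same holds across everything shown: the limit of > 80000 nM in this assay, at which 3 of the 3 values shown sit. The compounds shown leave open how much compound each would actually need, and whether any group on the shared core would give a measurable number in this assay.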